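This account rests on a few compounds, and the source may have more. Where it says the series, first, only, none or still open, it means among the compounds named here.

Compound 2, `C[C@H](NC(=O)c1c(Cc2cccc(F)c2)sc2c1CCOC2)c1ccc(C(=O)O)cc1`, gives 5.1 nM in a functional assay on CHO/Galpha16 cells for antagonist activity at prostaglandin E2 receptor EP4 subtype (Homo sapiens), read by calcium flux, with a stated time of 15 min (on this read-out higher numbers stand for weaker inhibition and lower numbers for stronger inhibition), and stands second highest of the three numbers measured. Compound 3, `O=C(O)c1ccc(C2(NC(=O)c3c(Cc4cccc(C(F)(F)F)c4)sc4c3CCOC4)CC2)cc1`, gives 1 nM, lower by a step beyond the scatter, while compound 1, `CCC1CCc2c(sc(CCc3ccc(F)cc3)c2C(=O)N[C@@H](C)c2ccc(C(=O)O)cc2)C1`, gives 649 nM, far higher and also beyond the scatter. Compound 4, `C[C@H](NC(=O)c1c(C#Cc2ccc(F)cc2)sc2c1CCOC2)c1ccc(C(=O)O)cc1`, differs from compound 2 in one place: 2-(4-fluorophenyl)ethynyl in place of 3-fluorobenzyl on an aromatic carbon. Going by the values given here, no measured pair shows this kind of swap, so the size of the step is uncertain. Because compound 1 gives 649 nM with a different link to a fluorophenyl ring on a different core, a weaker result is expected here, and the expected step from compound 2 to compound 4 is a 5.9-fold higher number from compound 2 to compound 4 (0.77 log units; beyond the scatter). Compound 4 is thus estimated at 30 nM, within 5 nM to 200 nM.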

Compound 4, half-maximal inhibitory concentration: 15.8 nM
For compound 4 the middle estimate is 1.9-fold (0.28 log units) above the measured one; the measured number falls inside the stated range.
By their numbers in this assay, from the lowest: compound 3; then compound 2; then compound 4; then compound 1.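

At this position, on the aromatic carbon next to the ring sulfur, 2-(4-fluorophenyl)ethynyl in place of 3-fluorobenzyl gives a 3.1-fold higher number from compound 2 to compound 4 (0.49 log units; beyond the scatter), a modest weakening of inhibition in this assay. This single swap alters both the link to the ring and the place of the fluorine, so the step cannot be divided between them. Nothing available explains the step.

A 4-fluorobenzyl or 2-(3-fluorophenyl)ethynyl group at this position could separate those two changes. On these data alone, whether an unsubstituted phenylethynyl group would fit equally well also remains open.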